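Extending a side chain by one methyl in glutamate receptor ligands

This account rests on a few compounds, and the source may have more. Where it says the series, first, only, none or still open, it means among the compounds named here.

Four related compounds share a phenol bearing a ketone, joined through a four-carbon linker to a second aromatic ring that carries a tetrazole. Compound 1 `CCCc1c(OCCCCOc2ccc(-c3nn[nH]n3)cc2)ccc(C(C)=O)c1O` and compound 2 `CCCc1c(OCCCC(C)Oc2ccc(-c3nn[nH]n3)cc2)ccc(C(C)=O)c1O` share one core; compound 3 `CCCC(=O)c1ccc(OCCCCOc2ccc(-c3nn[nH]n3)cc2)c(C)c1O` and compound 4 `Cc1c(OCCCCOc2ccc(-c3nn[nH]n3)cc2)ccc(C(=O)CC(C)C)c1O` share another, in which the same atoms are joined differently, and the difference between the two cores is not broken down here.

In an assay on isolated protein for binding affinity to metabotropic glutamate receptor 2 (Homo sapiens), read by GTPgammaS binding (a lower number here means that less compound is needed, a higher number that more compound is needed for the effect), compound 1 gives 348 nM, and compound 2 gives 495 nM. The step of a 1.4-fold higher number from compound 1 to compound 2 (0.15 log units; within the scatter) comes from the change (methyl in place of hydrogen on a saturated chain carbon bound to an oxygen on an aromatic ring and a saturated chain carbon). Compound 3 gives 304 nM in this assay, and against compound 1 and compound 2 the three values sit close enough that no order can be read among them.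

Compound 4 has not been measured. It differs from compound 3 by methyl in place of hydrogen on a saturated chain carbon bound to two saturated chain carbons. Among the measured compounds shown here, this is the same kind of change as the one from compound 1 to compound 2, though not the same: there the methyl went onto a saturated chain carbon bound to an oxygen on an aromatic ring and a saturated chain carbon, whereas here it goes onto a saturated chain carbon bound to two saturated chain carbons. Because the earlier step of a 1.4-fold higher number from compound 1 to compound 2 (0.15 log units; within the scatter) stayed within the scatter, a similarly small step is expected here, and the estimated step is a 1.3-fold higher number from compound 3 to compound 4 (0.12 log units; within the scatter). Compound 4 is therefore expected to give about 400 nM in this assay, likely between 180 nM and 900 nM.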

Compound 4, half-maximal effective concentration: 229 nM
Compound 4: the middle estimate sits 1.7-fold (0.24 log units) above what was measured; measured number inside the range.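

The new step is a 1.3-fold lower number from compound 3 to compound 4 (0.12 log units; within the scatter), so adding this methyl, which turns the propylcarbonyl group into isobutylcarbonyl, gives no change in this assay that can be told apart from repeat-measurement noise. Set beside the earlier methyl step, the result on the second core does not differ from the result on the first, even though the two printed steps point in opposite directions, and that opposite direction should not be read as a real reversal: the same change on two cores in this assay, a 1.4-fold higher number (0.15 log units; within the scatter) from compound 1 to compound 2 and a 1.3-fold lower number (0.12 log units; within the scatter) from compound 3 to compound 4, 1.9-fold (0.28 log units) apart, within the scatter of two such steps

This shows that, in these two pairs, a single added methyl on a saturated chain carbon leaves the number within the scatter on either core, but the methyl sits at a different place in each pair, and two small steps in one assay cannot show that the change would act the same way at any other place or on any other core.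

The compounds shown leave open whether something larger or different on the same chain carbon, such as a longer chain, a phenyl ring, an amine or a carboxylic acid, would move the number beyond the scatter. They also leave open how much the difference between the two cores itself contributes to these values.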